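The source may report more compounds than this note shows. Statements on the series, on what has been measured and on what is new or still open speak of the compounds shown alone.

For the measured compounds named here, in an in vitro ADME assay on microsomes from liver (Macaca fascicularis) for metabolic stability (on this read-out higher numbers stand for fast clearance and lower numbers for slow clearance), compound 1 (`CC[C@H](C)[C@@H]1C(=O)N[C@H](C2Cc3ccccc3C2)C(=O)N1[C@@H](C(=O)N(C)C)c1ccc(C)nc1C`) gives 14 mL.min-1.g-1, while compound 2 (`CC[C@H](C)[C@@H]1C(=O)N[C@H](C2Cc3ccccc3C2)C(=O)N1[C@@H](C(=O)N(C)C)c1ccc(C)[n+]([O-])c1`) gives 1 mL.min-1.g-1, the lower of the only two numbers so far. Compound 3 (`CC[C@H](C)[C@@H]1C(=O)N[C@H](C2Cc3ccccc3C2)C(=O)N1[C@@H](C(=O)N(C)C)c1cnc(C)cc1C`) has not yet been measured. Its difference from compound 2 is this: a group of 8 heavy atoms (7 carbon, 1 nitrogen; one six-membered aromatic ring with 1 hetero atom) in place of a group of 8 heavy atoms (6 carbon, 1 nitrogen, 1 oxygen; one six-membered aromatic ring with 1 hetero atom), on a saturated chain carbon bound to an amide-type nitrogen in a ring and a carbonyl carbon. The entering 4,6-dimethylpyridin-3-yl matches the group on compound 1 in its counted make-up, though the two are not the same group. Going by the values given here, only one measured step bears on the change: a 14-fold lower number from compound 1 to compound 2 (1.15 log units; beyond the scatter), a large step at the same place, and the new change runs the opposite way. A large rise in this assay is therefore expected, back towards the level of compound 1 at 14 mL.min-1.g-1. Among the compounds with values here, no measured compound shows what the different ring arrangement alone does. For compound 3 the estimated value is 12 mL.min-1.g-1, with an expected range of 5 mL.min-1.g-1 to 28 mL.min-1.g-1. The expected step is a 12-fold higher number from compound 2 to compound 3 (1.08 log units; beyond the scatter).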

Compound 3, intrinsic clearance in microsomes: 32 mL.min-1.g-1
Compound 3: middle estimate off by 2.7-fold (0.43 log units), on the low side; the whole stated range lies below it.
By their numbers in this assay, from the lowest: compound 2; then compound 1; then compound 3.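

In this assay the new group gives a 32-fold higher number from compound 2 to compound 3 (1.51 log units; beyond the scatter), so the low number of compound 2 is not shared by either dimethylpyridinyl group tested at this position. For the compounds shown here, the two dimethylpyridinyl groups are also not interchangeable: 4,6-dimethylpyridin-3-yl in place of 2,6-dimethylpyridin-3-yl gives a 2.3-fold higher number from compound 1 to compound 3 (0.36 log units; beyond the scatter), a real but much smaller step than the one from compound 2. Among these compounds, therefore, the arrangement of the methyl groups on the ring shifts the number modestly, while the low value belongs to compound 2 alone.

Nothing available explains either step. The compounds shown do not separate the effect of the oxygen in the group of compound 2 from that of its lower carbon count, a question that a 6-methylpyridin-3-yl group at this position could help to settle.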